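This account rests on a few compounds, and the source may have more. Where it says the series, first, only, none or still open, it means among the compounds named here.

For the measured compounds named here, in a functional assay on MCF7 cells (Homo sapiens) for inhibition, read by fluorescence, with a stated time of 72 h (a higher number here means a weaker inhibitor, a lower number a stronger inhibitor), only one of the three compounds measured so far has given an actual number. Compound 1 (`CC(C)Cn1cnc2c(NC(=N)N)nc(N)nc21`) gives 96600 nM. Compound 2 (`N=C(N)Nc1nc(N)nc2c1ncn2CCO`) gives > 100000 nM, which is a limit of the assay and not a number. Compound 3 (`CC[C@@H](N)COc1nc(NC(=N)N)c2ncn(C(C)C)c2n1`) gives > 100000 nM, which is also a limit and not a number. Compound 3 therefore has no exact position and stands at the limit of > 100000 nM in this assay, at which 2 of the 3 values shown sit.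

Compound 4 (`CC(C)[C@H](N)COc1nc(NC(=N)N)c2ncn(C(C)C)c2n1`) has not yet been measured. It carries 1-amino-2-methylpropyl in place of the 1-aminopropyl of compound 3, on a saturated chain carbon bound to an oxygen on an aromatic ring: 1-amino-2-methylpropyl in place of 1-aminopropyl on a saturated chain carbon bound to an oxygen on an aromatic ring. Put another way, 2-aminobutoxy becomes 2-amino-3-methylbutoxy.

Going by the values given here, no measured step involves this change. Among the compounds with values here, the only measured step is an at least 1.0-fold higher number from compound 1 to compound 2 (0.01 log units; that floor lies within the scatter), and it comes with hydroxymethyl in place of isopropyl on a saturated chain carbon bound to an aromatic nitrogen, a different place in the molecule. This gives only weak guidance, and on that step no shift beyond the scatter is expected in this assay, in either direction. The expected size is a number no higher from compound 3 to compound 4 (the limit leaves the size open). For compound 4 the estimate is 100000 nM, with an expected range from 40000 nM to 250000 nM.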

Compound 4, half-maximal inhibitory concentration: 3400 nM
Compound 4: the middle estimate sits 29-fold (1.47 log units) above what was measured; the whole stated range lies above it.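

In this assay, replacing 1-aminopropyl with 1-amino-2-methylpropyl, on a saturated chain carbon bound to an oxygen on an aromatic ring, gives an at least 29-fold lower number from compound 3 to compound 4 (1.46 log units; beyond the scatter). For the compounds shown here, this is the first step that lies beyond the scatter, and it shows that this position responds strongly to a small change: the group grows only from 4 heavy atoms to 5, with the same count of hydrogen-bond donors and acceptors. Compound 3 sits at a limit and not at a number, so the step gives only a floor and its true size stays open: the limit of > 100000 nM in this assay, at which 2 of the 4 values shown sit.

With a single pair at this position, the compounds shown cannot tell whether the gain follows from the branching itself or simply from the added carbon, and they do not show whether a tert-butyl or a phenyl group carried at the same chain carbon would lower the number further. They also leave open whether the amine is needed, as a hydroxyl in its place would test, and what the opposite configuration at the defined stereocentre would give.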